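This account rests on a few compounds, and the source may have more. Where it says the series, first, only, none or still open, it means among the compounds named here.

In a functional assay on NCI-H1581 cells (Homo sapiens) for antiproliferative activity, read by CCK-8 assay, with a stated time of 72 h (a higher number here means a weaker inhibitor, a lower number a stronger inhibitor), compound 1 `COc1cc(OC)c(Cl)c(-c2ccc3c(NC(=O)c4ccc(N5CCCCC5)cc4)n[nH]c3n2)c1Cl` gives 558 nM, the highest of the three numbers recorded there. Compound 2 `COc1cc(OC)c(Cl)c(-c2ccc3c(NC(=O)c4ccc(N5CCN(C(C)=O)CC5)cc4)n[nH]c3n2)c1Cl` gives 43.3 nM in this assay, and compound 3 `COc1cc(OC)c(Cl)c(-c2ccc3c(NC(=O)c4ccc(N5CCN(C)CC5)c(Cl)c4)n[nH]c3n2)c1Cl` gives 191 nM, so the number for compound 3 sits below that of compound 1 by a margin beyond the scatter, while compound 2 lies furthest from compound 1 of all. Compound 4 `COc1cc(OC)c(Cl)c(-c2ccc3c(NC(=O)c4ccc(N(C)CCN(C)C)cc4)n[nH]c3n2)c1Cl` differs from compound 1 in one place: (2-(dimethylamino)ethyl)(methyl)amino in place of piperidin-1-yl on an aromatic carbon. Going by the values given here, no measured pair carries exactly this entering group. Among the compounds with values here, the one measured step that bears on the change is a 13-fold lower number from compound 1 to compound 2 (1.11 log units; beyond the scatter), a large move toward a stronger inhibitor when a group holding a second nitrogen took the place of piperidin-1-yl; compound 3, whose ring also holds a second nitrogen, stands below compound 1 as well. On that basis a step toward a lower number is expected for compound 4, though a smaller and less certain one than the measured step, since an open chain rather than a ring now enters. The expected step is a 5.1-fold lower number from compound 1 to compound 4 (0.71 log units; beyond the scatter). In this assay compound 4 is estimated at 110 nM, with a range from 30 nM to 400 nM.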

Compound 4, half-maximal inhibitory concentration: 11 nM
Compound 4: the middle estimate sits 10-fold (1.00 log units) above what was measured; measured number outside the range, below it.
By their numbers in this assay, from the lowest: compound 4; then compound 2; then compound 3; then compound 1.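

In this assay, the aromatic carbon para to a large group accepts an open chain in place of a ring: (2-(dimethylamino)ethyl)(methyl)amino replacing piperidin-1-yl gives a 51-fold lower number from compound 1 to compound 4 (1.71 log units; beyond the scatter). The earlier step at this position, a 13-fold lower number from compound 1 to compound 2 (1.11 log units; beyond the scatter), came from one ring replacing another, so it could not show whether a ring was needed there. The chain also outdoes the 4-acetylpiperazin-1-yl ring, with a 3.9-fold lower number from compound 2 to compound 4 (0.60 log units; beyond the scatter), which shows that a low number at this position does not depend on keeping a ring, although nothing shown here accounts for the gain.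

The compounds shown leave open which part of the chain carries this step, for instance whether the terminal dimethylamino group could be exchanged for a pyrrolidine ring or a methoxy group, or whether a shorter or longer chain would give a similar number. They also leave open how a simple 4-methylpiperazin-1-yl ring would compare with the chain on the same core, without the added chlorine of compound 3.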